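The source may report more compounds than this note shows. Statements on the series, on what has been measured and on what is new or still open speak of the compounds shown alone.

Compound 1 `O=c1[nH]cc(S(=O)(=O)Nc2ccccc2-c2cn(-c3ccccc3)nn2)c(=O)[nH]1` and compound 2 `Cc1cccc(-n2cc(-c3ccccc3NS(=O)(=O)c3c[nH]c(=O)[nH]c3=O)nn2)c1` share one core, while compound 3 `O=c1[nH]cc(S(=O)(=O)Nc2ccc(-c3cn(-c4ccccc4)nn3)cc2)c(=O)[nH]1` is built from the same atoms joined in a different way; the difference between the two cores is not broken down here. In a functional assay on HepG2 cells (Homo sapiens) for antiproliferative activity, read by MTT assay, with a stated time of 24 h (on this read-out lower numbers stand for stronger inhibition and higher numbers for weaker inhibition), compound 1 gives 6160 nM, and compound 2 gives 3620 nM. In this assay compound 3 gives 18000 nM, the highest number among the three measured compounds. The change from compound 1 to compound 2 is methyl in place of hydrogen on an aromatic carbon, and it made a 1.7-fold lower number from compound 1 to compound 2 (0.23 log units; within the scatter). Compound 4 `Cc1ccccc1-n1cc(-c2ccc(NS(=O)(=O)c3c[nH]c(=O)[nH]c3=O)cc2)nn1` differs from compound 3 by methyl in place of hydrogen on an aromatic carbon. This is the same kind of change, yet the surroundings differ: in compound 2 the methyl sits meta to a large group, whereas in compound 4 it sits ortho to a large group. Among the compounds with values here, only one earlier instance of this kind of change has been measured, and it lay within the scatter, so a small step is expected again. The step expected here is a 1.5-fold lower number from compound 3 to compound 4 (0.18 log units; within the scatter). Compound 4 is thus expected to give about 12000 nM, with a range from 5000 nM to 30000 nM.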

Compound 4, half-maximal inhibitory concentration: 14500 nM
Compound 4: middle estimate off by 1.2-fold (0.08 log units), on the low side; the measured number falls inside the stated range.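

In this assay the swap from phenyl to 2-methylphenyl gives a 1.2-fold lower number from compound 3 to compound 4 (0.09 log units; within the scatter) and thus leaves the numbers of the pair indistinguishable. Set side by side, the methyl step on the two cores gives the same small result: the same change on two cores in this assay, a 1.7-fold lower number (0.23 log units; within the scatter) from compound 1 to compound 2 and a 1.2-fold lower number (0.09 log units; within the scatter) from compound 3 to compound 4, 1.4-fold (0.14 log units) apart, within the scatter of two such steps. So in this series, a methyl on this outer ring can be carried from one core to the other and its step stays too small to read, but two pairs with the methyl in different places do not show that either position improves activity, nor that the same would hold on any further core.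

The compounds shown leave open whether a group other than methyl at this ring, such as a chlorine atom, a methoxy group, an amine or a carboxylic acid, would give a step beyond the scatter. They also leave open whether a longer chain there, such as ethyl or propyl, would behave like the methyl on both cores.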